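From trifluoromethoxy to ethoxy on the shared core

This account rests on a few compounds, and the source may have more. Where it says the series, first, only, none or still open, it means among the compounds named here.

In a functional assay on MCF7 cells (Homo sapiens) for antiproliferative activity, read by MTT assay, with a stated time of 72 h (a higher number here means a weaker inhibitor, a lower number a stronger inhibitor), compound 1 (`COc1ccc(-c2ncnn2-c2cc(OC)c(OC)c(OC)c2)cc1`) gives 360 nM. Compound 2 (`COc1cc(-n2ncnc2-c2ccc(OC(F)(F)F)cc2)cc(OC)c1OC`) reads > 10000 nM, a limit of the assay and not a number, and so stands at the limit of > 10000 nM in this assay, at which 1 of the 2 values shown sits. Compound 3 (`CCOc1ccc(-c2ncnn2-c2cc(OC)c(OC)c(OC)c2)cc1`) differs from it by ethyl in place of trifluoromethyl on an oxygen on an aromatic ring. Within the data shown here, the one measured step that bears on this is an at least 27-fold higher number from compound 1 to compound 2 (1.44 log units; beyond the scatter), with trifluoromethyl in place of methyl at that oxygen. Removing trifluoromethyl is therefore expected to undo much of that large step in this assay. The expected change is an at least 12-fold lower number from compound 2 to compound 3 (1.09 log units; beyond the scatter), towards a lower number. For compound 3 the estimate is 800 nM, with an expected range of 200 nM to 5000 nM.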

Compound 3, half-maximal inhibitory concentration: 50 nM
For compound 3 the middle estimate is 16-fold (1.20 log units) above the measured one, and the stated range ends above it.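

In this assay this oxygen carries a chain longer than methyl with a gain, a 7.2-fold lower number from compound 1 to compound 3 (0.86 log units; beyond the scatter). The loss seen with trifluoromethyl is therefore not shared by ethyl, an at least 200-fold lower number from compound 2 to compound 3 (2.30 log units; beyond the scatter). The reading for compound 2 is a limit and not a number, so that step has no exact size: the limit of > 10000 nM in this assay, at which 1 of the 3 values shown sits.

On these data alone, whether the gain continues with a longer chain such as propyl stays open. So does the outcome with a ring or an amine at this oxygen, and with ethyl on a different core.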